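The source may hold more compounds than are shown below. What is called first, only, known or untested is meant among the compounds shown, and "the series" means these compounds.

Measured in a functional assay on MCF7 cells (Homo sapiens) for cytotoxicity, read by MTT assay; a lower number here means a stronger inhibitor, a higher number a weaker inhibitor:

- Compound 1 `COc1ccc(OC)c(C(=O)/C=C/c2ccco2)c1`: 10500 nM
- Compound 2 `COc1ccc(OC)c(C(=O)/C=C/c2cccs2)c1`: 3800 nM
- Compound 3 `COc1ccc(OC)c(C(=O)/C=C/c2ccsc2)c1`: 3700 nM

These three compounds share a core and differ only in the ring on the double-bonded chain. Compound 3, at 3700 nM, has the lowest of the three numbers, but it cannot be separated from compound 2, since the two lie within the scatter of each other. Both stand clearly apart from compound 1.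

The next compound is compound 4 `COc1ccc(OC)c(C(=O)/C=C/c2ccc(C)s2)c1`, and the change is 5-methylthiophen-2-yl in place of thiophen-3-yl on a double-bonded chain carbon bound to a double-bonded chain carbon. Two measured steps swap furan-2-yl for a thiophene ring: a 2.8-fold lower number from compound 1 to compound 2 (0.44 log units; beyond the scatter) and a 2.8-fold lower number from compound 1 to compound 3 (0.45 log units; beyond the scatter). Both are modest, and both lie beyond the scatter. The step that bears most directly is a 1.0-fold lower number from compound 2 to compound 3 (0.01 log units; within the scatter), which lies within the scatter, so the choice between thiophen-2-yl and thiophen-3-yl made no visible difference in these two compounds. Among the compounds with values here, that leaves the methyl of 5-methylthiophen-2-yl as the untested part, and no measured step covers it. As far as these compounds go, no step beyond the scatter is therefore expected in this assay, though either direction remains open. The estimate amounts to an expected 1.2-fold lower number from compound 3 to compound 4 (0.09 log units; within the scatter). For compound 4 the expected value is 3000 nM, with an estimated range of 1100 nM to 8500 nM.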

Compound 4, half-maximal inhibitory concentration: 2600 nM
Beside the measured number, compound 4's estimate is 1.2-fold (0.06 log units) above it, and the stated range covers the measured number.
By their numbers in this assay, from the lowest: compounds 4, 3 and 2 (each within the scatter of the next); then compound 1.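

The methyl of 5-methylthiophen-2-yl now has a measured step of its own: in this assay, methyl in place of hydrogen on an aromatic carbon gives a 1.5-fold lower number from compound 2 to compound 4 (0.16 log units; within the scatter) and so leaves the number within the scatter. Exchanging thiophen-3-yl for 5-methylthiophen-2-yl gives a 1.4-fold lower number from compound 3 to compound 4 (0.15 log units; within the scatter) and is also within the scatter, so compound 2, compound 3 and compound 4 cannot be separated in this assay, whereas a 4.0-fold lower number from compound 1 to compound 4 (0.61 log units; beyond the scatter) shows that the methylated ring, like the two unsubstituted thiophene rings, stands clearly apart from furan-2-yl. No measurement offered here accounts for either the lack of a clear methyl effect or the separation from compound 1.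

As far as these compounds go, a single methyl is only a small probe, so it remains open whether an ethyl, a longer chain, an amine or a carboxylic acid in place of that methyl would also stay within the scatter. From the compounds shown here alone, it is equally open whether a methyl on furan-2-yl would leave the number unmoved or would bring it closer to those of the thiophene compounds.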